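Benzimidazole-linked diaminoquinazolines: aryl variation at the azole

The compounds below may be only part of what the source reports. "The series", "measured", "known", "first", "only" and "open" are said of these compounds alone.

Measured so far in an assay on isolated protein for inhibition of Dihydrofolate reductase (Homo sapiens), read by spectrophotometry, using NADPH, with a stated time of 10 min; on this read-out lower numbers stand for stronger inhibition and higher numbers for weaker inhibition:
- compound 1 `Cc1cc2nc(-c3nccs3)n(-c3ccc4c(N)nc(N)nc4c3)c2cc1C`: 93 nM
- compound 2 `Cc1cc2nc(-c3cccs3)n(-c3ccc4c(N)nc(N)nc4c3)c2cc1C`: 1030 nM
- compound 3 `Cc1cc2nc(-c3ccncc3)n(-c3ccc4c(N)nc(N)nc4c3)c2cc1C`: 437 nM

Compound 3 stands second highest of the three numbers. Its nearest neighbour is compound 2, which lies a 2.4-fold lower number from compound 2 to compound 3 (0.37 log units; beyond the scatter); the furthest is compound 1, which lies a 4.7-fold higher number from compound 1 to compound 3 (0.67 log units; beyond the scatter). The widest step in the set is an 11-fold higher number from compound 1 to compound 2 (1.04 log units; beyond the scatter).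

Compound 4 `COc1ccc(-c2nc3cc(C)c(C)cc3n2-c2ccc3c(N)nc(N)nc3c2)cc1` is not yet measured. It differs from compound 3 in one place: 4-methoxyphenyl in place of pyridin-4-yl on an aromatic carbon.

For the measured compounds named here, no measured step exchanges pyridin-4-yl for 4-methoxyphenyl, so none bears directly on this change. What the set does show is that the two groups without a ring nitrogen next to the attachment, thiophen-2-yl in compound 2 and pyridin-4-yl in compound 3, give the two higher numbers, while 1,3-thiazol-2-yl in compound 1 gives the lowest. Compound 4 carries a carbon-only six-membered ring, which places it closer to compound 2 and compound 3 than to compound 1. The expected step is therefore small, at most a modest rise, a 1.5-fold higher number from compound 3 to compound 4 (0.17 log units; within the scatter).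

Compound 4 is estimated at 650 nM in this assay, with a range from 200 nM to 2200 nM.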

Compound 4, inhibition constant: 2300 nM
The estimate for compound 4 lay 3.5-fold (0.55 log units) below the measured number, and the stated range ends below it.
By their numbers in this assay, from the lowest: compound 1; then compound 3; then compound 2; then compound 4.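

In this assay, 4-methoxyphenyl on this aromatic carbon between two ring nitrogen atoms gives the highest number of the four compounds, with a 5.3-fold higher number from compound 3 to compound 4 (0.72 log units; beyond the scatter), a 2.2-fold higher number from compound 2 to compound 4 (0.35 log units; beyond the scatter) and a 25-fold higher number from compound 1 to compound 4 (1.39 log units; beyond the scatter). The position therefore tolerates less than the first three compounds suggested: the top of the range now lies past thiophen-2-yl, and the gap from 1,3-thiazol-2-yl is wider than any seen before. Two six-membered aromatic rings also part clearly here, so ring size alone does not set the number, with pyridin-4-yl in compound 3 well below 4-methoxyphenyl in compound 4, and nothing available accounts for this rise or for the order of the four groups.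

As far as these compounds go, the step from compound 3 to compound 4 removes the ring nitrogen and adds the methoxy group in a single change, so the share of each remains open, and a plain phenyl ring at this position would separate the two. Also open, from the compounds shown here alone, is how the number responds to a phenyl ring carrying an amine or a carboxylic acid in place of the methoxy group.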